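Microsomal stability notes: methyl replaced by a cyclic ether

A few compounds are considered here, and "the series" means these few. Any claim that something is new, unique, unknown or untested is made for them only; others in the source may bear on it.

Measured so far in an ADME assay on microsomes from liver (Rattus norvegicus) for metabolic stability, with a stated time of 60 min, tested at 1 uM; on this read-out higher numbers stand for a more stable compound and lower numbers for a less stable compound:
Compound 1 `COc1cc(-c2cnn3cc(OC)c(C(C)(C)O)nc23)ccn1`: 92%
Compound 2 `COc1cc(-c2cnn3cc(OC)c(C)nc23)ccn1`: 13%

Within the data shown here, compound 2 stands lowest of the two numbers in this assay; its only neighbour is compound 1, which sits far above it. Among the measured compounds shown here, the single measured step, a number 79 percentage points lower from compound 1 to compound 2 (beyond the scatter), came with methyl in place of 1-hydroxy-1-methylethyl on an aromatic carbon, and it lies well beyond the scatter.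

Compound 3 `COc1cc(-c2cnn3cc(OC)c([C@H]4COC(C)(C)C4)nc23)ccn1` differs from compound 2 by a group of 7 heavy atoms (6 carbon, 1 oxygen; one five-membered non-aromatic ring with 1 hetero atom) in place of one carbon atom, on an aromatic carbon. The step of a number 79 percentage points lower from compound 1 to compound 2 (beyond the scatter) bears on this directly, since it shows the methyl at this carbon going with a far lower number than a larger oxygen-bearing group there. The entering group in compound 3 also brings one oxygen, as a hydrogen-bond acceptor without a donor, so a full return to the level of compound 1 is uncertain. Compound 3 is therefore expected to rise by a number 42 percentage points higher from compound 2 to compound 3 (beyond the scatter), to an estimated 55% (range 20% to 90%).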

Compound 3, percent of the compound remaining: 30%
The estimate for compound 3 lay 25 percentage points above the measured number, and the stated range covers the measured number.
By their numbers in this assay, from the lowest: compound 2; then compound 3; then compound 1.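

In this assay, the cyclic ether at this aromatic carbon gives a number 17 percentage points higher from compound 2 to compound 3 (beyond the scatter), so a second replacement for methyl also goes with a higher number, though the gain is modest. Against 1-hydroxy-1-methylethyl, the same ring gives a number 62 percentage points lower from compound 1 to compound 3 (beyond the scatter), which shows that a larger group with an oxygen at this carbon does not by itself reach the level of compound 1; the ring brings a hydrogen-bond acceptor but no donor. No measurement at hand accounts for either step.

The compounds shown do not separate the hydroxyl of compound 1 from the branched carbon that carries it. From the compounds shown here alone, a tert-butyl group at this carbon would bear on that question in this assay, and how an amine there would stand also remains open.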